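The compounds below may be only part of what the source reports. "The series", "measured", "known", "first", "only" and "open" are said of these compounds alone.

Working notes on the series, all values from a functional assay on HT-29 cells (Homo sapiens) for inhibition, read by sulforhodamine B assay, with a stated time of 48 h; on this read-out lower numbers stand for stronger inhibition of growth and higher numbers for weaker inhibition of growth

Compound 1 `c1cc(NC2=NCCO2)cc(OC2CCCCC2)c1` gives 4400 nM
Compound 2 `O=C(CCl)NC(=O)Nc1cccc(OC2CCCC2)c1` gives 3100 nM

Compound 2 stands at 3100 nM, and compound 1 at 4400 nM lies within the scatter of it, so the two numbers do not separate.

Compound 3 `O=C(CCl)NC(=O)Nc1cccc(OC2CCCCC2)c1` has not yet been measured. It keeps the rest of compound 2 and carries cyclohexyl in place of cyclopentyl on an oxygen on an aromatic ring. Among the measured compounds shown here, no two measured compounds differ in one place only, so the series gives no direct measure of this change. Compound 1 carries the same cyclohexyloxy on a different core and gives 4400 nM, which offers only indirect support for expecting a number of similar size for compound 3.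

In this assay no step beyond the scatter is expected, and the estimated change is a 1.1-fold lower number from compound 2 to compound 3 (0.04 log units; within the scatter). For compound 3 the estimated value is 2800 nM (range 1300 nM to 6000 nM) .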

Compound 3, concentration for 50% growth inhibition: 3800 nM
Compound 3: middle estimate off by 1.4-fold (0.13 log units), on the low side; the measured number falls inside the stated range.
By their numbers in this assay, from the lowest: compounds 2, 3 and 1 (each within the scatter of the next).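

In this assay the change from cyclopentyl to cyclohexyl on an oxygen on an aromatic ring now has a direct measure, a 1.2-fold higher number from compound 2 to compound 3 (0.09 log units; within the scatter), so the two rings do not separate at this position on this core. Among the compounds shown here, with cyclohexyloxy held constant, the group on a nitrogen on an aromatic ring can also be read directly for the first time, a 1.2-fold lower number from compound 1 to compound 3 (0.06 log units; within the scatter), so the group without a ring in compound 3 and the five-membered ring with 2 hetero atoms in compound 1 do not separate either. No measured property of these compounds bears on this result, which therefore remains a comparison of growth-inhibition numbers alone.

As far as these compounds go, whether any group on this oxygen would give a step beyond the scatter stays open, for instance a phenyl ring, a methyl group or a longer chain carrying an amine. On the nitrogen side, the compounds shown do not tell whether the chlorine of the group in compound 3 matters, as no direct counterpart with hydrogen or fluorine in its place appears among them.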